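This account rests on a few compounds, and the source may have more. Where it says the series, first, only, none or still open, it means among the compounds named here.

In an assay on HEK293 cells for inhibition of prostaglandin E2 receptor EP2 subtype (Rattus norvegicus) (on this read-out lower numbers stand for stronger inhibition and higher numbers for weaker inhibition), compound 2, whose structure is `CC(C)(C)c1ccc(CN(Cc2cccc(CCC(=O)O)c2)S(=O)(=O)c2nccs2)cc1`, gives 63 nM, the lowest number among the compounds measured here. Compound 3, with the structure `CCCCc1ccc(CN(Cc2cccc(CCC(=O)O)c2)S(C)(=O)=O)cc1`, gives 270 nM in this assay. Compound 1, with the structure `CC(C)(C)c1ccc(CN(Cc2cccc(CCC(=O)O)c2)S(=O)(=O)c2ccc(Cl)cc2)cc1`, gives only a limit of the assay in this assay, > 3200 nM, so no number is known for it. Within the data shown here, the one step measured is an at least 50-fold lower number from compound 1 to compound 2 (1.70 log units; beyond the scatter), which is large.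

Compound 4, whose structure is `CC(C)(C)c1ccc(CN(Cc2cccc(CCC(=O)O)c2)S(=O)(=O)c2ccccc2)cc1`, differs from compound 2 in one place: phenyl in place of 1,3-thiazol-2-yl on a sulfonyl sulfur. This change runs back toward compound 1, since both phenyl and 4-chlorophenyl are six-membered carbon rings on the sulfonyl sulfur, and the step of an at least 50-fold lower number from compound 1 to compound 2 (1.70 log units; beyond the scatter) went strongly the other way. A large rise in the number is therefore expected, although phenyl is not 4-chlorophenyl and the size of the step is uncertain. The expected step is a 24-fold higher number from compound 2 to compound 4 (1.38 log units; beyond the scatter). For compound 4 the estimate in this assay is 1500 nM, between 300 nM and 6400 nM.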

Compound 4, half-maximal inhibitory concentration: 278 nM
Beside the measured number, compound 4's estimate is 5.4-fold (0.73 log units) above it; the measured number lies below the stated range.
By their numbers in this assay, from the lowest: compound 2; then compounds 3 and 4 (each within the scatter of the next). At a limit, above all of these: compound 1.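

Hydrogen in place of chloro on an aromatic carbon gives an at least 11-fold lower number from compound 1 to compound 4 (1.06 log units; beyond the scatter) in this assay, so much of the poor result for the 4-chlorophenyl group goes with the chloro and not with having a six-membered carbon ring on the sulfonyl sulfur. The change of ring alone has a smaller effect, a 4.4-fold higher number from compound 2 to compound 4 (0.64 log units; beyond the scatter), so 1,3-thiazol-2-yl keeps its advantage over phenyl, but by a modest margin. The size of the chloro step is only a lower bound, because compound 1 stands at a limit of the assay: the limit of > 3200 nM in this assay, at which 1 of the 4 values shown sits.

From the compounds shown here alone, it remains open whether a fluoro or a methyl on the phenyl ring would raise the number as chloro does. Also open, going by these compounds, is whether another ring on the sulfonyl sulfur, such as pyridyl, would match 1,3-thiazol-2-yl.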